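Swapping an alkyl tail for a phenyl-capped chain

The source may hold more compounds than are shown below. What is called first, only, known or untested is meant among the compounds shown, and "the series" means these compounds.

Of the compounds shown here, two with the same β-lactam carbamate core have been tested in an assay on HEK293 cells for inhibition of N-acylethanolamine-hydrolyzing acid amidase (Homo sapiens), read by fluorescence, with stated times of 10 min and 50 min; on this read-out lower numbers stand for stronger inhibition and higher numbers for weaker inhibition. Compound 1 `O=C(N[C@H]1CNC1=O)OCc1ccc(-c2cocn2)cc1` gives 1880 nM, while compound 2 `CCCCCCCCOC(=O)N[C@H]1CNC1=O` gives 37 nM, the lower of the two numbers and therefore the stronger inhibitor by a margin well beyond the usual scatter. Going by the values given here, no pair of measured compounds differs in only one place, so no single structural step has a measured size here.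

Compound 3 `O=C(N[C@H]1CNC1=O)OCCCCCc1ccccc1` is the untested analogue. The change from compound 2 is phenyl in place of propyl on a saturated chain carbon, five bonds along the chain from an oxygen next to a carbonyl group, so the overall length of the tail is kept while its end becomes aromatic. Among the compounds with values here, with no measured step to lean on, and compound 2 already giving 37 nM, the expectation is a step of a 1.9-fold lower number from compound 2 to compound 3 (0.27 log units; within the scatter) in this assay, a small move toward stronger inhibition that may stay within the scatter. Compound 3 is expected to give 20 nM, within 6 nM to 70 nM.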

Compound 3, half-maximal inhibitory concentration: 298 nM
Compound 3: middle estimate off by 15-fold (1.17 log units), on the low side; measured number above the stated range.
By their numbers in this assay, from the lowest: compound 2; then compound 3; then compound 1.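

In this assay, the end of the tail on the shared core turns out to matter: phenyl in place of propyl on a saturated chain carbon, five bonds along the chain from an oxygen next to a carbonyl group, gives an 8.1-fold higher number from compound 2 to compound 3 (0.91 log units; beyond the scatter), a move toward weaker inhibition. Going by these compounds alone, the two earlier compounds differ in more than one place, so they could not show the size of any single change, and this is the first such step measured at this position. Nothing available here explains why the number rises.

With only one replacement shown, it remains open whether the weaker inhibition comes from the aromatic ring itself or simply from a larger end group. A cyclohexyl group or a longer chain at the same place would help separate these two readings.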